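The compounds below may be only part of what the source reports. "The series", "measured", "known", "first", "only" and "open" are said of these compounds alone.

The series rests on the shared core of compound 1 `COc1nc(C)c2c(C)ncnc2c1C#N`, tested in a functional assay on KB cells (Homo sapiens) for cytotoxicity, read by MTT assay, with a stated time of 3 days; on this read-out lower numbers stand for stronger inhibition and higher numbers for weaker inhibition. In this assay compound 1 gives > 50000 nM, which is a limit of the assay and not a number. Compound 2 `C=C1c2c(C)nc(OC)c(C#N)c2N=CN1CC` carries an ethyl group on the core; in this assay compound 2 gives > 50000 nM, also a limit. Compound 3 `C=C1c2c(C)nc(OC)c(C#N)c2N=CN1CCC` carries a propyl group in its place, and in this assay compound 3 gives > 50000 nM, again a limit. The step that the two limits leave unreadable from compound 2 to compound 3 therefore cannot be read, since both ends sit at the limit, and the limit of > 50000 nM in this assay, at which 3 of the 3 values shown sit, shows that every value in the set sits there. Compound 3 thus stands exactly where the other two measured compounds stand: at a limit, with no number behind it.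

Compound 4 `C=C1c2c(C)nc(OC)c(C#N)c2N=CN1Cc1ccccc1` differs from compound 3 by phenyl in place of ethyl on a saturated chain carbon bound to an amine nitrogen in a ring. For the measured compounds named here, no measured step bears on this change, and the only step in the set is itself unreadable. With all three values at the limit, no direction and no size can be drawn from the data for this assay. Compound 4 is expected to stay near that limit, with an estimated step that the limit leaves unreadable from compound 3 to compound 4, giving an estimated value of 60000 nM and an expected range from 20000 nM to 200000 nM.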

Compound 4, half-maximal inhibitory concentration: > 50000 nM
Compound 4: a limit, no number; the forecaster's own chance of this, stated with the estimate: 80%; the middle value is on the limit's open side.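

In this assay compound 4 gives > 50000 nM, which is a limit of the assay and not a number. No step among compound 2, compound 3 and compound 4 can be read, since each value sits at the same limit: the limit of > 50000 nM in this assay, at which 4 of the 4 values shown sit.

The compounds shown leave open how these three rank against one another, and which change to the shared core would give a measurable value.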